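Working notes: from compound 3 to compound 4

The compounds below may be only part of what the source reports. "The series", "measured", "known", "first", "only" and "open" are said of these compounds alone.

Measured so far in an assay on isolated protein for inhibition of RAC-alpha serine/threonine-protein kinase (Homo sapiens), tested at 30 uM; a higher number here means more inhibition at the concentration tested (going by the name of the read-out), a lower number less inhibition:
compound 1 `Cn1cnc2c(Nc3ccc(F)cc3)ncnc21` gives 0%
compound 2 `c1ccc(CSc2ncnc3[nH]cnc23)cc1` gives 4%
compound 3 `Clc1ncnc2ncn(Cc3ccccc3)c12` gives 0%

Compound 3 stands level with compound 1 at the digits read, and the number of compound 2 sits a few points higher, a gap that lies within the usual scatter of this assay. Among the compounds with values here, on these three numbers no compound can be set apart from the others; the whole set reads as essentially no inhibition at the concentration tested.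

The next member, compound 4 `Fc1ccc(Cn2cnc3ncnc(Cl)c32)cc1`, differs from compound 3 in one place: fluoro in place of hydrogen on an aromatic carbon. Within the data shown here, no step between measured compounds follows a change of this kind, so nothing here speaks for a shift in either direction. The step of a number 2 percentage points higher from compound 3 to compound 4 (within the scatter) is therefore expected to be none beyond the scatter. Compound 4 is accordingly estimated at 2% in this assay, with a range from -6% to 12%.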

Compound 4, a percentage reported as inhibition, at one concentration (the size of the read-out at that concentration, not a potency): 0%
The estimate for compound 4 lay 2 percentage points above the measured number; the range from low to high includes it.
By their numbers in this assay, from the lowest: compounds 1, 3, 4 and 2 (each within the scatter of the next).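

In this assay fluoro in place of hydrogen on an aromatic carbon, para to a large group, now has a direct reading at this position, with the step of no change at the digits printed from compound 3 to compound 4 (within the scatter). With compound 3 and compound 4 both reading no inhibition at the concentration tested, fluoro at this place does not lift the read-out beyond the scatter, but the step cannot show whether fluoro would matter on a compound with clear inhibition. No measurement at hand bears on why the read-out stays at this level.

Open, from the compounds shown here alone, is whether another group at this place, such as an amine, a carboxylic acid or a longer chain, would give a read-out beyond the scatter. Also open, going by these compounds, is how the same fluoro step would read on a compound with clear inhibition in this assay.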